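Aryl hydrazones: trifluoromethyl in place of bromo

This account rests on a few compounds, and the source may have more. Where it says the series, first, only, none or still open, it means among the compounds named here.

Measured so far in a functional assay on the whole organism for inhibition, with Rattus norvegicus as the target; a lower number here means that less compound is needed, a higher number that more compound is needed for the effect:
compound 1 `CC1CC/C(=N\Nc2cccc(Cl)c2)c2ncc(C(=O)O)c(=O)n21`: > 100 umol/kg
compound 2 `CC1CC/C(=N\Nc2ccccc2Br)c2ncc(C(=O)O)c(=O)n21`: > 320 umol/kg
compound 3 `CC1CC/C(=N\Nc2ccc(Br)cc2)c2ncc(C(=O)O)c(=O)n21`: > 1000 umol/kg

Every value shown here is a limit of the assay and not a number. For compound 1 the value > 100 umol/kg is a limit. For compound 2 the value > 320 umol/kg is a limit. For compound 3 the value > 1000 umol/kg is a limit, so compound 3 stands at a limit, as do the two further values shown, and no ordering among the three can be read. The steps a step that the two limits leave unreadable from compound 1 to compound 2, a step that the two limits leave unreadable from compound 1 to compound 3 and a step that the two limits leave unreadable from compound 2 to compound 3 are therefore unreadable in size and direction; the limits (the limit of > 100 umol/kg in this assay, at which 1 of the 3 values shown sits), the limit of > 320 umol/kg in this assay, at which 1 of the 3 values shown sits, and the limit of > 1000 umol/kg in this assay, at which 1 of the 3 values shown sits, are all that the data hold.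

Compound 4 `CC1CC/C(=N\Nc2ccc(C(F)(F)F)cc2)c2ncc(C(=O)O)c(=O)n21` is not yet measured. Relative to compound 3 the change is trifluoromethyl in place of bromo on an aromatic carbon. The three unreadable steps are the only ones bearing on it; they give no size, only that chloro or bromo on the aryl ring gave no readable value. No step beyond the scatter is expected in this assay, and another limit is the likely outcome. The expected step is a number no higher from compound 3 to compound 4 (the limit leaves the size open), none beyond the scatter. Compound 4 is estimated at 1000 umol/kg, with a range from 300 umol/kg to 3000 umol/kg.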

Compound 4, dose for 50% inhibition: > 1000 umol/kg
Compound 4 gave a limit, no number (the forecaster's own chance of this, stated with the estimate: 80%); the middle value sits exactly at the limit.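

Going by these compounds alone, compound 4 gives > 1000 umol/kg in this assay, a limit and not a number, so no step from compound 3 to compound 4 can be read in size or direction. Both compounds stand at the same limit: the limit of > 1000 umol/kg in this assay, at which 2 of the 4 values shown sit.

The compounds shown leave open whether any aryl substituent here gives a readable value in this assay.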